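The source may report more compounds than this note shows. Statements on the series, on what has been measured and on what is new or still open speak of the compounds shown alone.

Measured compounds:
Compound 1, `COc1cc2c(Oc3ccc(NC(=O)c4nn(-c5ccccc5)c(=O)c5ccccc45)cc3F)ccnc2cc1OCCCN1CCCCC1`: 1310 nM
Compound 2, `COc1cc2c(Oc3ccc(NC(=O)c4nn(-c5ccc(Br)cc5)c(=O)c5ccccc45)cc3F)ccnc2cc1OCCCN1CCCCC1`: 770 nM

In a functional assay on HT-29 cells (Homo sapiens) for cytotoxicity, read by MTT assay, with a stated time of 72 h (on this read-out higher numbers stand for weaker inhibition and lower numbers for stronger inhibition), compound 2 gives 770 nM, and compound 1 gives 1310 nM. Going by the values given here, the two numbers sit within the scatter of each other, since the only measured step, a 1.7-fold lower number from compound 1 to compound 2 (0.23 log units; within the scatter), does not exceed it; compound 2 therefore cannot be set apart from compound 1 on these data.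

Compound 3, `COc1cc2c(Oc3ccc(NC(=O)c4nn(-c5ccc([N+](=O)[O-])cc5)c(=O)c5ccccc45)cc3F)ccnc2cc1OCCCN1CCCCC1`, differs from compound 2 in one place: nitro in place of bromo on an aromatic carbon. Among the compounds with values here, no measured step covers this exchange. Within the data shown here, the one step that bears on it at all, a 1.7-fold lower number from compound 1 to compound 2 (0.23 log units; within the scatter), concerns a different substituent entering the same position on the same ring, and it stayed within the scatter. On that basis no step beyond the scatter is expected in this assay from compound 2 to compound 3, in either direction.

Compound 3 is therefore estimated at 900 nM in this assay, with a range from 350 nM to 2500 nM. This estimate means an expected 1.2-fold higher number from compound 2 to compound 3 (0.07 log units; within the scatter).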

Compound 3, half-maximal inhibitory concentration: 2170 nM
Beside the measured number, compound 3's estimate is 2.4-fold (0.38 log units) below it; the measured number falls inside the stated range.
By their numbers in this assay, from the lowest: compounds 2, 1 and 3 (each within the scatter of the next, the first and the last beyond it).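

In this assay, going by these compounds alone, the change from 4-bromophenyl to 4-nitrophenyl gives the first step at this position that lies beyond the scatter, a 2.8-fold higher number from compound 2 to compound 3 (0.45 log units; beyond the scatter), so the two substituents can be told apart here, though only modestly. Hydrogen cannot be separated from nitro on these data, since a 1.7-fold higher number from compound 1 to compound 3 (0.22 log units; within the scatter) stays within the scatter, as does a 1.7-fold lower number from compound 1 to compound 2 (0.23 log units; within the scatter); only the two substituents differ from each other, with compound 1 lying within the scatter of both. Nothing available explains the gap between bromo and nitro.

The compounds shown leave open how an amine, a methoxy group or a carboxylic acid would read at this same place on the ring. They also leave open whether chloro or another halogen would fall with bromo, and whether any group could move the number beyond the scatter from that of compound 1.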